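Swapping the phenyl ester substituent on a sulfonate

The compounds below may be only part of what the source reports. "The series", "measured", "known", "first", "only" and "open" are said of these compounds alone.

Measured in a functional assay on HT-29 cells (Homo sapiens) for antiproliferative activity, read by sulforhodamine B assay, with a stated time of 48 h; a lower number here means a stronger inhibitor, a higher number a weaker inhibitor:
compound 1, `Cc1ccccc1OS(=O)(=O)c1ccc(N2CCN(C)C2=O)cc1`, gives 4800 nM.
compound 2, `CN1CCN(c2ccc(S(=O)(=O)Oc3cccc(F)c3)cc2)C1=O`, reports only the assay's limit, > 100000 nM.
compound 3, `CCCN1CCN(c2ccc(S(=O)(=O)Oc3ccccc3C)cc2)C1=O`, reports only the assay's limit, > 100000 nM.

Compound 3 therefore stands at the least active end of what has been seen: its result is a limit, not a number, and it shares that limit with one other compound (the limit of > 100000 nM in this assay, at which 2 of the 3 values shown sit). The step from compound 1 to compound 3, an at least 20-fold higher number from compound 1 to compound 3 (1.31 log units; beyond the scatter), shows how the ethyl in place of hydrogen on a saturated chain carbon bound to an amide-type nitrogen in a ring alone pushes the result to the limit.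

The new compound 4, `CCCN1CCN(c2ccc(S(=O)(=O)Oc3cccc(Cl)c3)cc2)C1=O`, differs from compound 3 in one place: 3-chlorophenyl in place of 2-methylphenyl on an oxygen. The closest measured precedent is the step from compound 1 to compound 2, an at least 20-fold higher number from compound 1 to compound 2 (1.31 log units; beyond the scatter), where a halogen-bearing phenyl in place of 2-methylphenyl on the same oxygen made the compound much weaker. Both pieces of evidence point the same way, so the 3-chlorophenyl is expected to give no gain at all, leaving compound 4 at or beyond the limit.

The expected step from compound 3 to compound 4 is a step that the limit leaves unreadable from compound 3 to compound 4, essentially none beyond the scatter. Compound 4 is estimated at 150000 nM, with a range from 50000 nM to 500000 nM.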

Compound 4, half-maximal inhibitory concentration: 13000 nM
Compound 4: middle estimate off by 12-fold (1.06 log units), on the high side; measured number below the stated range.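

In this assay, the phenyl group on the oxygen bound to the sulfonyl sulfur can bring back measurable activity as well as remove it: 3-chlorophenyl in place of 2-methylphenyl gives an at least 7.6-fold lower number from compound 3 to compound 4 (0.88 log units; beyond the scatter). The earlier exchange at this same place ran the other way, with 3-fluorophenyl in place of 2-methylphenyl giving an at least 20-fold higher number from compound 1 to compound 2 (1.31 log units; beyond the scatter), so losing 2-methylphenyl does not have one fixed outcome across the compounds shown. The new step can be read only as a minimum, because compound 3 carries a limit and not a number: the limit of > 100000 nM in this assay, at which 2 of the 4 values shown sit.

From the compounds shown here alone, the two exchanges differ both in the halogen that enters and in the chain on the amide-type nitrogen in the ring, so it remains open which of the two decides the direction, and how 3-chlorophenyl would behave with the shorter chain of compound 1. Also open, going by these compounds, are why this exchange lowers the number at all and whether the gain extends to other groups on the phenyl ring, such as an amine or a carboxylic acid.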